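This account rests on a few compounds, and the source may have more. Where it says the series, first, only, none or still open, it means among the compounds named here.

Working notes on the series. Two compounds have been run in a functional assay on HEK293 cells for agonist activity at Neuronal acetylcholine receptor; alpha3/beta4 (Homo sapiens), read by FLIPR (a higher number here means that more compound is needed for the effect, a lower number that less compound is needed), so far. Compound 1 `c1cncc(N2C[C@H]3CCNC[C@H]32)c1` gives 1540 nM in this assay. Compound 2 `Clc1ccc(N2C[C@@H]3CCNC[C@@H]32)cn1` gives 1390 nM in this assay, the lower of the two numbers, though the gap to compound 1 lies within the scatter, so no order between them can be claimed.

The next compound, compound 3 `Clc1ccc(N2C[C@H]3CCNC[C@H]32)cn1`, relates to compound 2 as follows: the two compounds have the same atoms and bonds and differ only in configuration as drawn: 2 of 2 stereo elements differ (all stereocentres are inverted: mirror images); a stereocentre at a saturated ring carbon is drawn S in compound 2 and R in compound 3; a stereocentre at a saturated ring carbon is drawn R in compound 2 and S in compound 3. Going by the values given here, nothing measured so far speaks to the effect of inverting both stereocentres on the shared core; compound 1 and compound 2 differ in more than one place, so their numbers give no guidance on this point. A step in this assay in either direction, or none beyond the scatter, is therefore possible, and the expectation is set near compound 2 with a wide range. Compound 3 is expected at 2500 nM, within 400 nM to 15000 nM, corresponding to an expected step of a 1.8-fold higher number from compound 2 to compound 3 (0.25 log units; within the scatter).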

Compound 3, half-maximal effective concentration: 1520 nM
Compound 3: the middle estimate sits 1.6-fold (0.22 log units) above what was measured; measured number inside the range.
By their numbers in this assay, from the lowest: compounds 2, 3 and 1 (each within the scatter of the next).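

In this assay, inverting both stereocentres on the shared core gives a 1.1-fold higher number from compound 2 to compound 3 (0.04 log units; within the scatter) and so separates this pair of mirror images by no more than the scatter. The comparison isolates configuration as the only variable, which compounds 1 and 2 could not do: the fact that compounds 2 and 3 differ only in the configuration as drawn. Chloro in place of hydrogen on an aromatic carbon can now also be read alone, and it gives a 1.0-fold lower number from compound 1 to compound 3 (0.01 log units; within the scatter) in the configuration shared by those two compounds, so this replacement likewise has no effect beyond the scatter.

As far as these compounds go, whether a bromo, methoxy or nitrile group at the chloro position would leave the number unchanged remains open. Also open, from the compounds shown here alone, is whether the mirror image of compound 1 would match compound 1 as closely as compound 2 matches compound 3.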